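Replacing the Amino Group of Compound 2 with Methoxymethyl

This account rests on a few compounds, and the source may have more. Where it says the series, first, only, none or still open, it means among the compounds named here.

Compound 1, `CC(C)=CCOc1cc(Nc2ncnc(Cl)n2)ccc1Cl`: 45000 nM in an ADME assay on MT2 cells (Homo sapiens) for cytotoxicity; on this read-out lower numbers stand for higher toxicity in this test and higher numbers for lower toxicity in this test
Compound 2, `CC(C)=CCOc1cc(Nc2nccc(N)n2)ccc1Cl`: 500 nM
Compound 3, `COc1cc(N)nc(Nc2ccc(Cl)c(OCC=C(C)C)c2)n1`: 19000 nM

Compound 2 gives the lowest number of the three in this assay, meaning the strongest cytotoxicity of this set; the nearest neighbour lies a 38-fold higher number from compound 2 to compound 3 (1.58 log units; beyond the scatter) away, and the step of a 90-fold lower number from compound 1 to compound 2 (1.95 log units; beyond the scatter) shows how far compound 2 sits from the furthest. Compound 4, `COCc1ccnc(Nc2ccc(Cl)c(OCC=C(C)C)c2)n1`, differs from compound 2 in one place: methoxymethyl in place of amino on an aromatic carbon. Neither measured step is this same change, but both alter the same part of the molecule and both were large, in opposite directions. The loss of the amino group with its hydrogen-bond donor is expected to move the number upward, though less surely than either measured step. Compound 4 is therefore estimated at 3000 nM, within 800 nM to 15000 nM, an expected step of a 6.0-fold higher number from compound 2 to compound 4 (0.78 log units; beyond the scatter).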

Compound 4, half-maximal cytotoxic concentration: > 25000 nM
Compound 4 ended at the assay's limit; the forecaster's own chance of this, stated with the estimate: 10%; middle value at least 8.3-fold (0.92 log units) from the limit.
By their numbers in this assay, from the lowest: compound 2; then compound 3; then compound 1.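

In this assay, methoxymethyl in place of amino on this aromatic carbon, next to the ring nitrogen, gives an at least 50-fold higher number from compound 2 to compound 4 (1.69 log units; beyond the scatter). Compound 3 keeps the amino group and also carries a higher number than compound 2, whereas this step shows that changing the amino group itself is enough to lose the low number of compound 2. Compound 4 stands at a limit of this assay, not at a number: the limit of > 25000 nM in this assay, at which 1 of the 4 values shown sits.

On these data alone, how far compound 4 lies past that limit stays open. Also open, as far as these compounds go, is whether the loss of amino or the arrival of methoxymethyl carries the step, which a methylamino or a plain methyl group at this carbon could separate.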